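A few compounds are considered here, and "the series" means these few. Any claim that something is new, unique, unknown or untested is made for them only; others in the source may bear on it.

Three compounds share one core and differ only in the aryl group on a saturated ring carbon. Compound 1 `CN1C(=O)C(c2cccc(Cl)c2)N(C)c2nc(Nc3ccc(S(N)(=O)=O)cc3)ncc21` gives 989 nM in an assay on Sf9 cells for inhibition of serine/threonine-protein kinase 4 (Homo sapiens), read by luminescence and ADP-Glo, with a stated time of 1 h, in the presence of a further agent that is not named here; on this read-out lower numbers stand for stronger inhibition and higher numbers for weaker inhibition; compound 2 `CN1C(=O)C(c2ccccc2F)N(C)c2nc(Nc3ccc(S(N)(=O)=O)cc3)ncc21` gives 75 nM in this assay; compound 3 `CN1C(=O)C(c2ccccc2Br)N(C)c2nc(Nc3ccc(S(N)(=O)=O)cc3)ncc21` gives 57 nM in this assay. Compound 3 has the lowest of the three numbers, but compound 2 sits within the scatter of it, while compound 1 lies far higher. Compound 4 `CN1C(=O)C(c2c(F)cccc2F)N(C)c2nc(Nc3ccc(S(N)(=O)=O)cc3)ncc21` carries 2,6-difluorophenyl in place of 2-bromophenyl on a saturated ring carbon. Going by the values given here, the steps that bear on this are a 13-fold lower number from compound 1 to compound 2 (1.12 log units; beyond the scatter) and a 17-fold lower number from compound 1 to compound 3 (1.24 log units; beyond the scatter), both large, and a 1.3-fold lower number from compound 2 to compound 3 (0.12 log units; within the scatter), which is within the scatter; no measured step adds a second fluorine. Because the step of a 1.3-fold lower number from compound 2 to compound 3 (0.12 log units; within the scatter) is small, compound 4 is expected to show a 1.1-fold higher number from compound 3 to compound 4 (0.02 log units; within the scatter). Compound 4 is therefore estimated at 60 nM in this assay, with a range from 25 nM to 150 nM.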

Compound 4, half-maximal inhibitory concentration: 42 nM
Compound 4: the middle estimate sits 1.4-fold (0.15 log units) above what was measured; measured number inside the range.
By their numbers in this assay, from the lowest: compounds 4, 3 and 2 (each within the scatter of the next); then compound 1.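

A second fluorine adds little at this position: a 1.8-fold lower number from compound 2 to compound 4 (0.25 log units; within the scatter), and replacing the bromine-bearing ring with the 2,6-difluorophenyl group gives a 1.4-fold lower number from compound 3 to compound 4 (0.13 log units; within the scatter), both within the scatter in this assay. The gap to the 3-chlorophenyl group persists, with a 24-fold lower number from compound 1 to compound 4 (1.37 log units; beyond the scatter), so 2-fluorophenyl, 2-bromophenyl and 2,6-difluorophenyl now sit together while compound 1 alone stands apart. Where an aminophenyl or a carboxyphenyl group on this carbon would fall stays open. Nothing available explains why the aryl groups divide this way.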